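The source may hold more compounds than are shown below. What is called first, only, known or untested is meant among the compounds shown, and "the series" means these compounds.

In an ADME assay on Vero cells (Chlorocebus sabaeus) for cytotoxicity, read by MTT assay, with a stated time of 72 h (on this read-out lower numbers stand for stronger inhibition and higher numbers for weaker inhibition), compound 1 `CCOC(=O)c1c(C)[n+]([O-])c2cc(F)c(F)cc2[n+]1[O-]` gives 30600 nM and compound 2 `Cc1c(C(=O)OCc2ccccc2)[n+]([O-])c2cc(F)c(F)cc2[n+]1[O-]` gives 55300 nM. Among the measured compounds shown here, compound 1 therefore stands level with its only measured neighbour, the step being a 1.8-fold higher number from compound 1 to compound 2 (0.26 log units; within the scatter). Compound 3 `CCOC(=O)c1c(C)[n+]([O-])c2cc(-n3cncn3)c(F)cc2[n+]1[O-]` alters the core of compound 1 at one point: 1H-1,2,4-triazol-1-yl in place of fluoro on an aromatic carbon. In words, this is 1H-1,2,4-triazol-1-yl in place of fluoro on an aromatic carbon, ortho to a fluoro group. For the measured compounds named here, no measured step touches that carbon. Going by the values given here, the single step available, a 1.8-fold higher number from compound 1 to compound 2 (0.26 log units; within the scatter), swaps methyl for phenyl at a different place, so it is only a loose guide. With nothing pointing either way, no step beyond the scatter is expected in this assay, although the uncertainty is wide. The expected step is a 1.0-fold lower number from compound 1 to compound 3 (0.01 log units; within the scatter). For compound 3 the estimate is 30000 nM, with an expected range from 10000 nM to 90000 nM.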

Compound 3, half-maximal inhibitory concentration: 155000 nM
For compound 3 the middle estimate is 5.2-fold (0.71 log units) below the measured one; measured number above the stated range.
By their numbers in this assay, from the lowest: compounds 1 and 2 (each within the scatter of the next); then compound 3.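

In this assay, the swap at this aromatic carbon, ortho to a fluoro group, gives a 5.1-fold higher number from compound 1 to compound 3 (0.70 log units; beyond the scatter), so what sits on this carbon can shift the number towards weaker inhibition of the cells. The only earlier step, a 1.8-fold higher number from compound 1 to compound 2 (0.26 log units; within the scatter), stayed within the scatter, which makes this the first change shown that clearly moves the number, here from a single fluoro atom to a 1H-1,2,4-triazol-1-yl group of five heavy atoms. Nothing given here explains the rise.

From the compounds shown here alone, it remains open whether the rise follows from losing the fluoro group or from gaining this particular ring, and an amine or a methoxy group on the same carbon would help separate the two. Going by these compounds, it is also open whether the same swap would shift the number similarly on compound 2.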